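A few compounds are considered here, and "the series" means these few. Any claim that something is new, unique, unknown or untested is made for them only; others in the source may bear on it.

Compound 1 `O=C(NCCCOc1ccc2nc(O)ccc2c1)N(C1CC1)[C@@H]1CCC[C@H]1O` gives 67% in a functional assay on the whole organism for inhibition, with Mus musculus as the target, at a dose of 30 mg/kg by the oral route; a lower number here means less inhibition, a higher number more inhibition at the dose given (going by the name of the read-out).
Compound 2 `O=C(NCCCOc1ccc2nc(O)ccc2c1)N(C1CC1)[C@@H]1CCC[C@@H](O)C1` gives 20% in this assay.
Compound 3 `O=C(NCCCOc1ccc2nc(O)ccc2c1)N(C1CC1)[C@H]1CCCC[C@H]1O` gives 100% in this assay.

In this assay compound 3 stands highest of the three measured compounds: a number 33 percentage points higher from compound 1 to compound 3 (beyond the scatter) and a number 80 percentage points higher from compound 2 to compound 3 (beyond the scatter), both beyond the scatter. Compound 4 `CCCCO[C@H]1CCCC[C@@H]1N(C(=O)NCCCOc1ccc2nc(O)ccc2c1)C1CC1` differs from compound 3 by 2-butoxycyclohexyl in place of 2-hydroxycyclohexyl on an amide-type nitrogen. For the measured compounds named here, none of the measured steps exchanges the hydroxy group for an ether; they only move the hydroxy group or change the ring size, as in a number 47 percentage points lower from compound 1 to compound 2 (beyond the scatter). They show that among compounds 1, 2 and 3 the placement of the hydroxy group goes with large differences in the read-out, but they do not show what follows when the hydrogen-bond donor is removed and a butoxy group enters. A downward step is expected, a number 50 percentage points lower from compound 3 to compound 4 (beyond the scatter), with wide uncertainty. Compound 4 is therefore estimated to give 50%, between 15% and 90%.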

Compound 4, a percentage reported as inhibition, in the whole organism at one dose (the size of the read-out at that dose, not a potency): 33%
Estimate against measurement, compound 4: 17 percentage points above; low and high end bracket the measured number.
By their numbers in this assay, from the lowest: compound 2; then compound 4; then compound 1; then compound 3.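

In this assay, putting 2-butoxycyclohexyl in place of 2-hydroxycyclohexyl on the amide-type nitrogen, which leaves this group with no hydrogen-bond donor, cost much of the read-out (a number 67 percentage points lower from compound 3 to compound 4 (beyond the scatter)). The butoxy ether still stood above the 3-hydroxycyclohexyl group (a number 13 percentage points higher from compound 2 to compound 4 (beyond the scatter)) but below the 2-hydroxycyclopentyl group (a number 34 percentage points lower from compound 1 to compound 4 (beyond the scatter)). The read-out at this position therefore does not vanish when the hydroxy group gives way to this ether. No evidence at hand explains the drop. From the compounds shown here alone, whether a methoxy group or an amine here would keep more of the read-out stays open.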